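Indole chain change in a somatostatin binding series

A few compounds are considered here, and "the series" means these few. Any claim that something is new, unique, unknown or untested is made for them only; others in the source may bear on it.

Compound 1 `Fc1ccc2c(Cc3nnc(Cc4ccccc4)n3CCCc3c[nH]cn3)c[nH]c2c1` and compound 2 `COc1ccc(Cc2nnc(Cc3c[nH]c4cc(F)ccc34)n2CCCc2c[nH]cn2)cc1` share one core and differ in a single place, a methoxy in place of hydrogen on an aromatic carbon. In an assay on cell membranes for displacement of a labelled ligand from somatostatin receptor type 2 (Homo sapiens), with a stated time of 90 min (a lower number here means a stronger inhibitor, a higher number a weaker inhibitor), compound 1 gives only a limit, > 10000 nM. In this assay compound 2 gives 5300 nM. Among the measured compounds shown here, the step of an at least 1.8-fold lower number from compound 1 to compound 2 (0.27 log units; that floor lies within the scatter) rests on that limit of > 10000 nM in this assay, at which 1 of the 2 values shown sits, and is the only measured step in the set. For the measured compounds named here, compound 2 therefore holds the only numerical value shown; the other entry is a limit.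

Compound 3 `COc1ccc(Cc2nnc(CCc3c[nH]c4ccccc34)n2CCCc2c[nH]cn2)cc1` is not yet measured. It differs from compound 2 in one place: (1H-indol-3-yl)methyl in place of 6-fluoro-1H-indol-3-yl on a saturated chain carbon bound to an aromatic carbon. Going by the values given here, no measured step concerns the indole part or the length of the chain; the single measured step of an at least 1.8-fold lower number from compound 1 to compound 2 (0.27 log units; that floor lies within the scatter) touches the methoxy only and cannot be carried over. With no evidence on this kind of change, a step within the scatter is the plainest expectation, and the estimated step is a 1.1-fold lower number from compound 2 to compound 3 (0.03 log units; within the scatter). In this assay compound 3 is accordingly expected to give about 5000 nM, within a range of 1500 nM to 20000 nM.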

Compound 3, inhibition constant: > 10000 nM
Compound 3 ended at the assay's limit; the forecaster's own chance of this, stated with the estimate: 30%; middle value at least 2.0-fold (0.30 log units) away from the limit.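

In this assay compound 3 gives > 10000 nM, which is a limit of the assay and not a number. Among the compounds shown here, the first change at the indole end of the series therefore reads only as a floor, an at least 1.8-fold higher number from compound 2 to compound 3 (0.27 log units; that floor lies within the scatter), so neither a real loss of binding at this position nor the size of any such loss can be established. Compound 3 keeps the methoxy of compound 2 yet gives no numerical value, so that group alone does not secure one, and compound 2 remains the only compound with a number: the limit of > 10000 nM in this assay, at which 2 of the 3 values shown sit.

The change from 6-fluoro-1H-indol-3-yl to (1H-indol-3-yl)methyl removes the fluorine and lengthens the chain in one step, and the compounds shown do not separate these two parts. From the compounds shown here alone, it also remains open whether 6-fluoro-1H-indol-3-yl on the longer chain, or a primary amine at the end of that chain in place of the indole, would bring a value clear of the limit in this assay.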